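The source may hold more compounds than are shown below. What is called first, only, known or untested is meant among the compounds shown, and "the series" means these compounds.

Measured so far in a physicochemical assay for permeability, using PAMPA, at pH 7.4; a lower number here means that the compound crosses the layer more slowly, a higher number that the compound crosses the layer faster: compound 3 `CC(C)(C)CNCCS(=O)(=O)NC(=O)c1ccc(Nc2nc(NC3(c4ccc(Cl)cc4)CC3)nc(OCC(F)(F)F)n2)cc1` gives 651 nm/s; compound 1 `CCS(=O)(=O)NC(=O)c1ccc(Nc2nc(NC3(c4ccc(Cl)cc4)CC3)nc(OCC(F)(F)F)n2)cc1` gives 28 nm/s; compound 2 `O=C(NS(=O)(=O)CCNC(=O)C1CC1)c1ccc(Nc2nc(NC3(c4ccc(Cl)cc4)CC3)nc(OCC(F)(F)F)n2)cc1` gives 1 nm/s.

Compound 3 stands highest of the three: it is a 23-fold higher number from compound 1 to compound 3 (1.37 log units; beyond the scatter) and a 650-fold higher number from compound 2 to compound 3 (2.81 log units; beyond the scatter), both well beyond the scatter. Compound 4 `CNC(=O)NCCS(=O)(=O)NC(=O)c1ccc(Nc2nc(NC3(c4ccc(Cl)cc4)CC3)nc(OCC(F)(F)F)n2)cc1` is reached from compound 3 by one change, (methylcarbamoyl in place of neopentyl on an amine nitrogen).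

Among the measured compounds shown here, two measured steps bear on this. The step from compound 2 to compound 3 exchanged one group on the same amine nitrogen for neopentyl and read a 650-fold higher number from compound 2 to compound 3 (2.81 log units; beyond the scatter); the step from compound 1 to compound 2, which installed the cyclopropylcarbonylamino group on the chain carbon, read a 28-fold lower number from compound 1 to compound 2 (1.45 log units; beyond the scatter). The group entering in compound 4, methylcarbamoyl, shares with cyclopropylcarbonyl a carbonyl, one hydrogen-bond acceptor, and an amide-type nitrogen, while the neopentyl that leaves carries no donor or acceptor. Compound 4 is therefore expected to behave far more like compound 2 than like compound 3, so a large downward step, a 330-fold lower number from compound 3 to compound 4 (2.51 log units; beyond the scatter), is expected in this assay. For compound 4 the estimate is 2 nm/s, with a range from 0.5 nm/s to 10 nm/s, near the low value of compound 2.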

Compound 4, apparent permeability: 40 nm/s
Compound 4: middle estimate off by 20-fold (1.30 log units), on the low side, outside the stated range (above it).
By their numbers in this assay, from the lowest: compound 2; then compounds 1 and 4 (each within the scatter of the next); then compound 3.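

In this assay, methylcarbamoyl in place of neopentyl on the amine nitrogen gives a 16-fold lower number from compound 3 to compound 4 (1.21 log units; beyond the scatter), a step beyond the scatter but smaller than the one between the cyclopropylcarbonyl and neopentyl groups on the same nitrogen, a 650-fold higher number from compound 2 to compound 3 (2.81 log units; beyond the scatter). A carbonyl on this nitrogen therefore does not by itself fix the reading: methylamino in place of cyclopropyl on the carbonyl carbon gives a 40-fold higher number from compound 2 to compound 4 (1.60 log units; beyond the scatter), so the group beyond the carbonyl matters at this position as well. The earlier compounds shown here showed large steps for every group placed on the saturated chain carbon, whereas (methylcarbamoyl)amino in place of hydrogen there gives a 1.4-fold higher number from compound 1 to compound 4 (0.15 log units; within the scatter), which lies within the scatter.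

No measured information on these groups is available to explain these steps. The compounds shown leave open whether the high reading of compound 3 belongs to neopentyl specifically or extends to other carbon groups on the same nitrogen, such as an ethyl or a cyclohexyl, and how a sulfonyl or a dimethylcarbamoyl group on that nitrogen would read.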